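The source may hold more compounds than are shown below. What is called first, only, known or untested is meant among the compounds shown, and "the series" means these compounds.

Working notes on the series.

Compound 1 `O=C(N/N=C\c1ccccc1)Nc1nnc(COc2ccc3ccccc3c2)o1` is tested in a functional assay on the whole organism (strain Swiss albino) with Mus musculus as the target, in the maximal electroshock model, with a stated time of 4 h (on this read-out higher numbers stand for an effect only at larger amounts of compound and lower numbers for an effect already at smaller amounts), and gives 300 mg/kg. Compound 2 `COc1ccc(/C(=N\NC(=O)Nc2nnc(COc3ccc4ccccc4c3)o2)c2ccccc2)cc1` in this assay gives 300 mg/kg, and compound 3 `O=C(N/N=C(/c1ccccc1)c1ccc([N+](=O)[O-])cc1)Nc1nnc(COc2ccc3ccccc3c2)o1` in this assay gives 300 mg/kg. Compound 1 therefore stands level with compound 2 and compound 3 on the numbers shown; its value lies within the scatter of both. Among the measured compounds shown here, the one step among measured compounds that differ in a single place, no change at the digits printed from compound 2 to compound 3 (within the scatter), concerns a nitro in place of a methoxy on an aromatic carbon and leaves the dose unchanged within the scatter.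

Compound 4 `C/C(=N/NC(=O)Nc1nnc(COc2ccc3ccccc3c2)o1)c1ccc(N)cc1` is not yet measured in this assay. It differs from compound 1 by a group of 10 heavy atoms (8 carbon, 2 nitrogen; one six-membered aromatic ring of carbon only) in place of a group of 8 heavy atoms (7 carbon, 1 nitrogen; one six-membered aromatic ring of carbon only), on an amide-type nitrogen. For the measured compounds named here, no measured step touches this part of the molecule; the only measured step, no change at the digits printed from compound 2 to compound 3 (within the scatter), sits elsewhere and shows no change. Going by the values given here, the series so far gives no example of a change on the amide-type nitrogen that moves the dose beyond the scatter, so no step beyond the scatter is expected, in either direction.

On that basis compound 4 is expected to give 300 mg/kg in this assay, with a range from 150 mg/kg to 600 mg/kg. The step this estimate means is no change at the digits printed from compound 1 to compound 4 (within the scatter), expected to be none beyond the scatter.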

Compound 4, minimum effective dose: 300 mg/kg
For compound 4 middle estimate and measured number coincide at the digits printed; measured number inside the range.
By their numbers in this assay, from the lowest: compounds 1, 2, 3 and 4 (each within the scatter of the next).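

Among the compounds shown here, the step of no change at the digits printed from compound 1 to compound 4 (within the scatter) in this assay is the first measured change on the amide-type nitrogen, and it shows that a group of 10 heavy atoms (8 carbon, 2 nitrogen; one six-membered aromatic ring of carbon only) can take the place of a group of 8 heavy atoms (7 carbon, 1 nitrogen; one six-membered aromatic ring of carbon only) with no step beyond the scatter. The entering group carries a hydrogen-bond donor that the leaving group lacks, and at this position that difference, like the larger heavy-atom count, comes with no step beyond the scatter. No measurement at hand bears on why this step stays within the scatter.

All four compounds still share one printed value, so no change shown so far, at this position or elsewhere, separates any compound from the others. Open, on these data alone, is whether a carboxylic acid on the aromatic ring, or a straight alkyl chain in place of that ring, would move the dose beyond the scatter at the amide-type nitrogen.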